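This account rests on a few compounds, and the source may have more. Where it says the series, first, only, none or still open, it means among the compounds named here.

Compound 3 `CC1=NC(C)=C(C(=O)O)C(c2cccc(Br)c2)/C1=C(\O)OC/C=C/c1ccccc1` gives 790 nM in a functional assay on IMR-32 cells for inhibition of Voltage-dependent N-type calcium channel subunit alpha-1B (Homo sapiens), read by calcium flux; on this read-out lower numbers stand for stronger inhibition and higher numbers for weaker inhibition. Against compound 1 `CC1=NC(C)=C(C(=O)O)C(c2cccc(C)c2)/C1=C(\O)OC/C=C/c1ccccc1`, with 1800 nM, the difference is a 2.3-fold lower number from compound 1 to compound 3 (0.36 log units; beyond the scatter); against compound 2 `CC1=NC(C)=C(C(=O)O)C(c2cccc(F)c2)/C1=C(\O)OC/C=C/c1ccccc1`, with 1300 nM, it is a 1.6-fold lower number from compound 2 to compound 3 (0.22 log units; within the scatter), and compound 1 to compound 2 is a 1.4-fold lower number from compound 1 to compound 2 (0.14 log units; within the scatter). Compound 4 `CC1=NC(C)=C(C(=O)O)C(c2cccnc2)/C1=C(\O)OC/C=C/c1ccccc1` carries pyridin-3-yl in place of 3-bromophenyl on a saturated ring carbon. For the measured compounds named here, none of the measured steps covers an exchange of the aromatic ring itself; all three only swap the substituent on an aromatic carbon, and the largest of them, from compound 1 to compound 3, was modest. The bromo that went with the lowest number is now gone, so a weaker result for compound 4 is expected, with a 3.2-fold higher number from compound 3 to compound 4 (0.50 log units; beyond the scatter). Compound 4 is thus estimated at 2500 nM, with a range of 900 nM to 7000 nM.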

Compound 4, half-maximal inhibitory concentration: 24000 nM
For compound 4 the middle estimate is 9.6-fold (0.98 log units) below the measured one; measured number outside the range, above it.
By their numbers in this assay, from the lowest: compounds 3, 2 and 1 (each within the scatter of the next, the first and the last beyond it); then compound 4.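

In this assay, replacing the aromatic ring moves the number much further than any substituent swap on it: (a 30-fold higher number from compound 3 to compound 4 (1.48 log units; beyond the scatter)), (an 18-fold higher number from compound 2 to compound 4 (1.27 log units; beyond the scatter)) and (a 13-fold higher number from compound 1 to compound 4 (1.12 log units; beyond the scatter)), all large, where the substituent swaps were modest at most. The pyridin-3-yl brings a ring nitrogen and a hydrogen-bond acceptor and also drops the ring substituent, so the two changes cannot be separated here. Nothing measured here accounts for the loss.

Open, going by these compounds, is how plain phenyl would sit, without any ring substituent. Also open, on these data alone, is whether pyridin-3-yl carrying bromo, or pyridin-4-yl, would give a similar number.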